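The compounds below may be only part of what the source reports. "The series", "measured", "known", "first", "only" and "open" are said of these compounds alone.

Working notes on the series.

Among the measured compounds shown here, compound 1 `CCOc1ccc(NC2=CC(=O)c3c(nc4n3[C@H]3OC[C@@H](O)[C@H]3OC4)C2=O)cc1` is the anchor: in a functional assay on MGC-803 cells (Homo sapiens) for inhibition, read by sulforhodamine B assay (on this read-out higher numbers stand for weaker inhibition and lower numbers for stronger inhibition), compound 1 gives 2090 nM, and this is the only value in the set that is a number rather than a limit. Compound 2 `O=C1C=C(NC2CCCCC2)C(=O)c2c1nc1n2[C@H]2OC[C@@H](O)[C@H]2OC1` carries cyclohexylamino on the core; in this assay compound 2 returns only the limit > 8000 nM. Compound 3 `O=C1C=C(N2CCCCC2)C(=O)c2c1nc1n2[C@H]2OC[C@@H](O)[C@H]2OC1` carries piperidin-1-yl in the same position; in this assay compound 3 likewise returns the limit > 8000 nM. For the measured compounds named here, the one measured step, a step that the two limits leave unreadable from compound 2 to compound 3, is therefore unreadable, since both ends sit at the limit of > 8000 nM in this assay, at which 2 of the 3 values shown sit. Nothing measured speaks to the aryl substituent itself.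

Compound 4 `O=C1C(Nc2ccc(Br)cc2)=CC(=O)c2c1nc1n2[C@H]2OC[C@@H](O)[C@H]2OC1` differs from compound 1 by bromo in place of ethoxy on an aromatic carbon, i.e. 4-ethoxyphenyl to 4-bromophenyl. Going by the values given here, no measured step bears on this change; the only step available concerns the amine side and is unreadable. The expectation for compound 4 therefore rests on compound 1 alone, with a wide allowance and no direction beyond the scatter, as a 1.0-fold lower number from compound 1 to compound 4 (0.02 log units; within the scatter) expresses. Compound 4 is estimated in this assay at 2000 nM, expected between 500 nM and 8000 nM.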

Compound 4, half-maximal inhibitory concentration: 2020 nM
The estimate for compound 4 lay 1.0-fold (0.00 log units) below the measured number; low and high end bracket the measured number.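

In this assay, the substituent on the phenyl ring now has a measured step of its own: a 1.0-fold lower number from compound 1 to compound 4 (0.01 log units; within the scatter). At this place, para to a large group, ethoxy with 3 heavy atoms and 1 hydrogen-bond acceptor leaves and bromo with 1 heavy atom and 0 hydrogen-bond acceptors enters, and the printed step still lies within the scatter, so for these two groups the read-out does not tell the substituents apart. Compound 1 and compound 4 both carry a substituted phenyl on the amine and are the only two compounds here with numbers, whereas compound 2 with cyclohexylamino and compound 3 with piperidin-1-yl stay at an assay limit that is not a number: the limit of > 8000 nM in this assay, at which 2 of the 4 values shown sit.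

The step from compound 2 to compound 3 cannot be read, so the amine side has no measured size of effect. On these data alone, whether the flat picture at the para place extends beyond ethoxy and bromo stays open, for instance to a carboxylic acid, a dimethylamino group or a longer chain such as butoxy on the same aromatic carbon.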